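Amine swap on the propoxy chain of the series

The source may report more compounds than this note shows. Statements on the series, on what has been measured and on what is new or still open speak of the compounds shown alone.

Compound 2 `COc1cc2c(Oc3ccc(NC(=O)c4nn(-c5ccccc5OC(F)(F)F)c(=O)cc4C)cc3F)ccnc2cc1OCCCN1CCCC1` gives the lowest of the two numbers recorded so far: in a functional assay on A549 cells (Homo sapiens) for inhibition, read by MTT assay, with a stated time of 72 h (a higher number here means a weaker inhibitor, a lower number a stronger inhibitor), compound 2 gives 140 nM. Compound 1 `COc1cc2c(Oc3ccc(NC(=O)c4nn(-c5ccccc5C)c(=O)cc4C)cc3F)ccnc2cc1OCCCN1CCC(C)CC1` differs from compound 2 in more than one place. In this assay, among the measured compounds shown here, compound 1 gives 1460 nM, a gap beyond the scatter; as no measured pair separates the two changes, the numbers show only that compound 1 is the weaker of the two, not which change accounts for the gap.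

Compound 3 `COc1cc2c(Oc3ccc(NC(=O)c4nn(-c5ccccc5OC(F)(F)F)c(=O)cc4C)cc3F)ccnc2cc1OCCCN1CCC(C)CC1` is not yet measured. It keeps the trifluoromethoxy group of compound 2 and takes over the amine of compound 1: 4-methylpiperidin-1-yl in place of pyrrolidin-1-yl on a saturated chain carbon, three bonds along the chain from an oxygen on an aromatic ring. For the measured compounds named here, no measured pair isolates this swap. The expected step in this assay is small, most likely a modest rise in the number, though a step within the scatter is also possible. For compound 3 the value in this assay is estimated at 250 nM, with a range from 90 nM to 700 nM. The step that this estimate means, a 1.8-fold higher number from compound 2 to compound 3 (0.25 log units; within the scatter), is expected to read as a somewhat weaker inhibitor.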

Compound 3, half-maximal inhibitory concentration: 90 nM
Estimate against measurement, compound 3: 2.8-fold (0.44 log units) above, and the stated range covers the measured number.
By their numbers in this assay, from the lowest: compounds 3 and 2 (each within the scatter of the next); then compound 1.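

With trifluoromethoxy held constant, the change from 3-(pyrrolidin-1-yl)propyl to 3-(4-methylpiperidin-1-yl)propyl gives a 1.6-fold lower number from compound 2 to compound 3 (0.19 log units; within the scatter) in this assay, so these two amines cannot be told apart at this position on the present numbers. Among the compounds shown here, with the 4-methylpiperidin-1-yl amine held constant, trifluoromethoxy in place of methyl on an aromatic carbon gives a 16-fold lower number from compound 1 to compound 3 (1.21 log units; beyond the scatter) and is the first isolated read of that change, which places the large step in this set on the aromatic carbon and not on the amine. No measurement at hand gives a reason for either step.

Still open, on these data alone, is whether the amine swap reads the same with methyl on that aromatic carbon, and whether a morpholin-4-yl or a dimethylamino group at the end of the same propyl chain would stay as close to these two amines. Also open, as far as these compounds go, is how chloro or methoxy on that aromatic carbon would compare with methyl and trifluoromethoxy, which would show whether the large step is particular to trifluoromethoxy.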